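A Side-Chain Swap and Liver Microsome Half-Life

The source may report more compounds than this note shows. Statements on the series, on what has been measured and on what is new or still open speak of the compounds shown alone.

In an ADME assay on microsomes from liver (Rattus norvegicus, strain Sprague-Dawley) for metabolic stability, read by LC-MS, using NADPH, with a stated time of 60 min, tested at 10 mM (on this read-out lower numbers stand for a shorter-lived compound and higher numbers for a longer-lived compound), compound 1 (`O=Cc1c(-c2nc(NCCCCN3CCCC3)c3ccccc3n2)[nH]c2ccccc12`) gives 4.13 h as its half-life. Compound 2 (`CCN(CC)CCCCNc1nc(-c2[nH]c3ccc(OC)cc3c2C=O)nc2ccccc12`) gives 4.28 h as its half-life, which puts it within the usual scatter of compound 1. Compound 3 (`COc1ccc2[nH]c(-c3nc(NCCN4CCCC4)c4ccccc4n3)c(C=O)c2c1`) has not yet been measured. It has pyrrolidin-1-yl in place of 2-(diethylamino)ethyl on a saturated chain carbon, two bonds along the chain from a nitrogen on an aromatic ring. For the measured compounds named here, no measured step shows what this change does, so an expected step of a 1.1-fold lower number from compound 2 to compound 3 (0.05 log units; within the scatter) stays within the scatter in this assay and has no firm direction. The estimate for compound 3 is 3.8 h with an expected range from 1.9 h to 7 h in this measurement.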

Compound 3, half-life: 1.75 h
Beside the measured number, compound 3's estimate is 2.2-fold (0.34 log units) above it; the measured number lies below the stated range.
By their numbers in this assay, from the lowest: compound 3; then compounds 1 and 2 (each within the scatter of the next).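

In this assay putting pyrrolidin-1-yl in place of 2-(diethylamino)ethyl gives a 2.4-fold lower number from compound 2 to compound 3 (0.39 log units; beyond the scatter) and so shows that this side chain can matter for half-life, which compounds 1 and 2 alone could not show. The change shortens the chain and brings in a ring at the same time, so the step cannot be divided between the two. Nothing measured here explains the step. From the compounds shown here alone, whether chain length or the ring counts more remains open. So does how a piperidine or morpholine ring at the chain end would behave.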